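Compound 3: Will a New Group Change a Low Reading?

The compounds below may be only part of what the source reports. "The series", "measured", "known", "first", "only" and "open" are said of these compounds alone.

In an ADME assay on microsomes from liver (Rattus norvegicus) for metabolic stability, using NADPH, with a stated time of 10 min (on this read-out lower numbers stand for a less stable compound and higher numbers for a more stable compound), compound 1 `CN(C[C@@H]1Cc2ncccc2CN1)[C@H]1CCCc2cccnc21` gives 1%. Compound 2 `NC(=O)NC/C=C/CN(C[C@H]1Cc2ncccc2CN1)[C@H]1CCCc2cccnc21` gives 1%, which is level with compound 1 and close to the bottom of the scale, so very little of either compound remains at the end of the test.

Compound 3 `c1cnc2c(c1)CN[C@@H](CN(CCCCNC1COC1)[C@H]1CCCc3cccnc31)C2` has not yet been measured. It differs from compound 2 in one group, on a saturated chain carbon bound to an amine nitrogen: a group of 8 heavy atoms (6 carbon, 1 nitrogen, 1 oxygen; one four-membered non-aromatic ring with 1 hetero atom) in place of a group of 7 heavy atoms (4 carbon, 2 nitrogen, 1 oxygen; no ring), on a saturated chain carbon bound to an amine nitrogen. The group that leaves has no ring, while the group that enters carries a four-membered non-aromatic ring with 1 hetero atom.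

Swapping one group can shift a reading like this, but two measured compounds give little to go on, and no measured step shows how large such a shift might be. Compound 2 at 1% leaves almost no room to fall, and neither measured compound shows a higher reading, so only a small rise is expected. The expected change is a number 2 percentage points higher from compound 2 to compound 3 (within the scatter), which would lie within the usual scatter. Compound 3 is estimated at 3%, with a likely range from 0% to 12%.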

Compound 3, percent of the compound remaining: 27%
For compound 3 the middle estimate is 24 percentage points below the measured one, outside the stated range (above it).
By their numbers in this assay, from the lowest: compounds 1 and 2 (each within the scatter of the next); then compound 3.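

In this assay, the replacement at this saturated chain carbon bound to an amine nitrogen gives a number 26 percentage points higher from compound 2 to compound 3 (beyond the scatter), so a change at this place can lift the reading clear of the bottom of the scale. Compounds 1 and 2 sat level and offered no sign of this, whereas this step shows that the position can respond, even though compound 3 at 27% still has most of its material gone by the end of the test. No supporting measurement is available to explain the rise.

The step changes several things at once: the group that leaves has no ring and 2 double bonds outside aromatic rings, while the group that enters carries a four-membered non-aromatic ring with 1 hetero atom, so the compounds shown cannot separate the contribution of the ring from that of the rest of the group. On these data alone, it remains open whether a plain butylamine chain without the ring, or a cyclobutyl ring with carbon in place of the ring oxygen, would give a similar reading, and whether a five-membered tetrahydrofuran ring would take it further.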